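The source may report more compounds than this note shows. Statements on the series, on what has been measured and on what is new or still open speak of the compounds shown alone.

Compound 1 `CC/N=C(\N)Nc1ccc(Sc2ccc(OC)cc2)cc1` is one of three compounds examined in an assay (Rattus norvegicus) for binding affinity to prostacyclin receptor (Homo sapiens), read by radioligand binding; a higher number here means a weaker inhibitor, a lower number a stronger inhibitor. In this assay compound 1 gives 251 nM, the second highest of the three numbers. Its closest neighbour is compound 2 `CC/N=C(\N)Nc1ccc(Sc2ccc(Cl)cc2)cc1`, which in this assay gives 631 nM; the step of a 2.5-fold higher number from compound 1 to compound 2 (0.40 log units; beyond the scatter) comes with chloro in place of methoxy on an aromatic carbon. The furthest is compound 3 `CCOc1ccc(Sc2ccc(NC3=NCCN3)cc2)cc1`, which in this assay gives 39.8 nM; compound 3 differs from compound 1 in more than one place, so only the two values themselves can be compared.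

Compound 4 `COc1ccc(Sc2ccc(C3=NCCN3)cc2)cc1` has not yet been measured. It differs from compound 1 in one way: a group of 5 heavy atoms (3 carbon, 2 nitrogen; one five-membered non-aromatic ring with 2 hetero atoms) in place of a group of 6 heavy atoms (3 carbon, 3 nitrogen; no ring), on an aromatic carbon. Among the measured compounds shown here, no measured step covers exactly this exchange. For the measured compounds named here, the only measured step, from compound 1 to compound 2, concerns the methoxy group and not this end of the molecule, so it offers little guidance. The values of compound 1 and compound 3 show that a compound carrying a five-membered ring with two hetero atoms in this region can reach a lower number, though compound 3 also differs elsewhere. A step of moderate size toward a lower number is therefore expected, a 2.5-fold lower number from compound 1 to compound 4 (0.40 log units; beyond the scatter), with wide uncertainty. Compound 4 is estimated at 100 nM, in a range from 25 nM to 400 nM.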

Compound 4, inhibition constant: 316 nM
Compound 4: middle estimate off by 3.2-fold (0.50 log units), on the low side; the range from low to high includes it.
By their numbers in this assay, from the lowest: compound 3; then compounds 1, 4 and 2 (each within the scatter of the next, the first and the last beyond it).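

In this assay, the exchange at this position, a group of 5 heavy atoms with one five-membered non-aromatic ring with 2 hetero atoms in place of an open group of 6 heavy atoms with no ring, gives a 1.3-fold higher number from compound 1 to compound 4 (0.10 log units; within the scatter), so the two groups cannot be told apart here. Among the compounds shown here, this is the first reading at this end of the molecule taken with the rest of the structure held fixed, and it shows that this position tolerates closing the open group into a ring, with the counts moving from 2 hydrogen-bond donors and 1 acceptor to 1 donor and 2 acceptors, without a step beyond the scatter. Nothing available bears on why the exchange leaves the reading within the scatter.

The compounds shown leave open whether a simple amine, an acetamide or a six-membered ring at the same aromatic carbon would read alike. They also leave open whether the step seen with chloro in place of methoxy would carry over to a compound bearing the five-membered ring.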